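The source may hold more compounds than are shown below. What is called first, only, known or untested is meant among the compounds shown, and "the series" means these compounds.

Of the compounds shown here, three of a shared core have been measured in an assay for binding affinity to Apoptosis regulator Bcl-2 (Homo sapiens), read by fluorescence polarization, with stated times of 30 min and 20 min, tested at 100 uM; a higher number here means more inhibition at the concentration tested (going by the name of the read-out), a lower number less inhibition. Compound 1, `O=C(Nc1cc(C(F)(F)F)cc(C(F)(F)F)c1)N1CCN(S(=O)(=O)c2sccc2-c2ccccc2Oc2ccc(O)c(O)c2)CC1`, gives 7% in this assay. Compound 3, `COc1ccc(Oc2ccccc2-c2ccsc2S(=O)(=O)N2CCN(C(=S)Nc3cc(C(F)(F)F)cc(C(F)(F)F)c3)CC2)cc1OC`, gives 25% in this assay. Compound 2, `COc1ccc(Oc2ccccc2-c2ccsc2S(=O)(=O)N2CCN(C(=O)Nc3cccc([N+](=O)[O-])c3)CC2)cc1OC`, gives 18% in this assay, which is the second highest of the three numbers: the nearest value is that of compound 3, a number within the scatter of it, so no order between compound 2 and compound 3 can be read from these two values; the furthest is that of compound 1, a number beyond the scatter and lower. Among the compounds with values here, none of the three compounds differs from another in a single place, so no step between measured compounds is available.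

Compound 4, `COc1ccc(Oc2ccccc2-c2ccsc2S(=O)(=O)N2CCN(C(=O)Nc3ccc(F)cc3)CC2)cc1OC`, is not yet measured in this assay. It differs from compound 2 in one place: 4-fluorophenyl in place of 3-nitrophenyl on an amide-type nitrogen. Within the data shown here, no measured pair shows the effect of this change, and all three measured numbers are low at the concentration tested. The step from compound 2 to compound 4 in this assay is therefore expected to be small, in either direction, and not beyond the scatter; the expected step is a number 3 percentage points lower from compound 2 to compound 4 (within the scatter). Compound 4 is estimated to give 15% in this assay, within a range from 4% to 28%.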

Compound 4, a percentage reported as inhibition, at one concentration (the size of the read-out at that concentration, not a potency): 15%
Compound 4: middle estimate and measured number agree at the digits printed; measured number inside the range.
By their numbers in this assay, from the lowest: compounds 1, 4, 2 and 3 (each within the scatter of the next, the first and the last beyond it).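

In this assay, the series now has its first step between compounds that differ in one place, a number 3 percentage points lower from compound 2 to compound 4 (within the scatter), and it concerns the group on the amide-type nitrogen. At this position, 3-nitrophenyl, which carries hydrogen-bond acceptors, can give way to 4-fluorophenyl, which carries none, without the two numbers being told apart, although both remain low at the concentration tested and a single-concentration read-out gives no potency. No measurement that bears on this result is available.

The compounds shown leave open whether this position would answer to a different kind of group, such as an amine or a carboxylic acid on the phenyl ring, or a longer alkyl chain in place of that ring. The other pairs differ in more than one place, so their steps cannot be read, and the separate contributions of the carbonyl and its sulfur counterpart, and of the groups on the far aryl ether ring, stay unresolved.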